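Arylamino variation on the shared core

The compounds below may be only part of what the source reports. "The series", "measured", "known", "first", "only" and "open" are said of these compounds alone.

In a functional assay on MCF7 cells (Homo sapiens) for inhibition, read by sulforhodamine B assay (a lower number here means a stronger inhibitor, a higher number a weaker inhibitor), the measured compounds stand as follows:
- compound 1 `O=C1C=C(N2CCC2)C(=O)c2c1nc1n2[C@H]2OC[C@@H](O)[C@H]2OC1` gives > 16000 nM as a limit
- compound 2 `COc1ccccc1NC1=CC(=O)c2nc3n(c2C1=O)[C@H]1OC[C@@H](O)[C@H]1OC3` gives > 4000 nM as a limit
- compound 3 `COc1ccc(NC2=CC(=O)c3nc4n(c3C2=O)[C@H]2OC[C@@H](O)[C@H]2OC4)cc1` gives 5420 nM as a number

Within the data shown here, compound 3 at 5420 nM holds the only true number here. The other two values are limits. Compound 4 `Cc1ccc(NC2=CC(=O)c3nc4n(c3C2=O)[C@H]2OC[C@@H](O)[C@H]2OC4)cc1C` differs from it by 3,4-dimethylphenyl in place of 4-methoxyphenyl on an amine nitrogen in words: 3,4-dimethylphenyl in place of 4-methoxyphenyl on an amine nitrogen. Among the measured compounds shown here, two measured steps bear on this. One is an at least 2.9-fold lower number from compound 1 to compound 3 (0.47 log units; beyond the scatter), but it replaces azetidin-1-yl, not a group on the aromatic ring. The other is a step that the limit leaves unreadable from compound 2 to compound 3, the only one between methoxyphenyl isomers, and it gives no size. No step beyond the scatter is therefore expected in this assay, in either direction, and the expected step is a 1.2-fold lower number from compound 3 to compound 4 (0.08 log units; within the scatter) for now. Compound 4 is estimated at 4500 nM with a range from 1500 nM to 13000 nM as the expected span.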

Compound 4, half-maximal inhibitory concentration: 2080 nM
Beside the measured number, compound 4's estimate is 2.2-fold (0.34 log units) above it; the range from low to high includes it.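

In this assay, among these compounds, there is a 2.6-fold lower number from compound 3 to compound 4 (0.42 log units; beyond the scatter) with the change to 3,4-dimethylphenyl on an amine nitrogen, the first readable step that alters the aromatic group alone. Compounds 1 and 2 give limits, not numbers. That leaves an at least 1.9-fold lower number from compound 2 to compound 4 (0.28 log units; that floor lies within the scatter) and an at least 7.6-fold lower number from compound 1 to compound 4 (0.88 log units; beyond the scatter) as floors only. Nothing measured here gives a cause for the step from compound 3.

Open remains which of the two methyl groups carries that step, and how 4-chlorophenyl or a phenyl bearing a carboxylic acid would read on this amine nitrogen.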